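Swapping the chloropyridine in a cell-growth inhibition series

This account rests on a few compounds, and the source may have more. Where it says the series, first, only, none or still open, it means among the compounds named here.

Measured so far:
compound 1 `Cc1noc(C)c1-c1cnc(N)c(Oc2ccc(C(=O)Nc3cccc(Cl)n3)cc2)n1` with 35700 nM
compound 2 `Cc1noc(C)c1-c1cnc(N)c(Oc2ccc(C(=O)Nc3ccc(Cl)cn3)cc2)n1` with 35600 nM
compound 3 `Cn1cc(-c2cnc(N)c(Oc3ccc(C(=O)Nc4cccc(Cl)n4)cc3)n2)cn1` with 44200 nM

All three were tested in a functional assay on HepG2 cells (Homo sapiens) for inhibition, read by MTT assay, with a stated time of 72 h; a lower number here means a stronger inhibitor, a higher number a weaker inhibitor. Compound 1 and compound 2 differ only in the change (5-chloropyridin-2-yl in place of 6-chloropyridin-2-yl on an amide-type nitrogen), and the step of a 1.0-fold lower number from compound 1 to compound 2 (0.00 log units; within the scatter) shows this change left the value essentially unchanged. Compound 1 and compound 3 differ in their cores by 1-methyl-1H-pyrazol-4-yl in place of 3,5-dimethyl-1,2-oxazol-4-yl on an aromatic carbon, and the step of a 1.2-fold higher number from compound 1 to compound 3 (0.09 log units; within the scatter) likewise stayed within the scatter.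

Compound 4 `Cn1cc(-c2cnc(N)c(Oc3ccc(C(=O)Nc4ccc(Cl)cn4)cc3)n2)cn1` is not yet measured. It differs from compound 3 by 5-chloropyridin-2-yl in place of 6-chloropyridin-2-yl on an amide-type nitrogen, the same change that turned compound 1 into compound 2, at the same place. Because the earlier step of a 1.0-fold lower number from compound 1 to compound 2 (0.00 log units; within the scatter) was flat, the step of a 1.0-fold lower number from compound 3 to compound 4 (0.00 log units; within the scatter) is expected to be flat as well. The value of compound 4 in this assay is therefore estimated at 44000 nM, between 22000 nM and 88000 nM.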

Compound 4, half-maximal inhibitory concentration: 24200 nM
Estimate against measurement, compound 4: 1.8-fold (0.26 log units) above, and the stated range covers the measured number.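

In this assay, the change to 5-chloropyridin-2-yl gives a 1.8-fold lower number from compound 3 to compound 4 (0.26 log units; within the scatter), which agrees with what the same change did on the other core: the same change on two cores in this assay, a 1.0-fold lower number (0.00 log units; within the scatter) from compound 1 to compound 2 and a 1.8-fold lower number (0.26 log units; within the scatter) from compound 3 to compound 4, 1.8-fold (0.26 log units) apart, within the scatter of two such steps. The change to 1-methyl-1H-pyrazol-4-yl, read here on the 5-chloropyridin-2-yl amides, gives a 1.5-fold lower number from compound 2 to compound 4 (0.17 log units; within the scatter), and it also agrees with its earlier step: the same change on two cores in this assay, a 1.2-fold higher number (0.09 log units; within the scatter) from compound 1 to compound 3 and a 1.5-fold lower number (0.17 log units; within the scatter) from compound 2 to compound 4, 1.8-fold (0.26 log units) apart, within the scatter of two such steps. Across these four compounds, neither change moves the number beyond the scatter, but steps this small do not show that a real effect carries from one core to another, and they say nothing about other cores.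

Still open, from the compounds shown here alone, is whether putting an amine or a carboxylic acid in place of the chlorine, or a plain phenyl in place of the 1-methyl-1H-pyrazol-4-yl, would move the number beyond the scatter.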